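Triazole aryl swap in the spirooxindole series

A few compounds are considered here, and "the series" means these few. Any claim that something is new, unique, unknown or untested is made for them only; others in the source may bear on it.

Among the measured compounds shown here, compound 1 `CCc1ccccc1-n1nncc1CN1C(=O)C2(C(C#N)=C(N)Oc3c(N)cc4nc5ccccc5nc4c32)c2ccccc21` is the stronger of the two measured members. In an ADME assay on L02 cells (Homo sapiens) for antiproliferative activity, read by MTT assay, with a stated time of 48 h (on this read-out higher numbers stand for weaker inhibition and lower numbers for stronger inhibition), compound 1 gives 22900 nM. Compound 2 `N#CC1=C(N)Oc2c(N)cc3nc4ccccc4nc3c2C12C(=O)N(Cc1cnnn1-c1ccccc1Cl)c1ccccc12` reaches only a limit of the assay: in this assay compound 2 gives > 50000 nM. For the measured compounds named here, the single measured step, an at least 2.1-fold higher number from compound 1 to compound 2 (0.33 log units; beyond the scatter), is bounded by the limit of > 50000 nM in this assay, at which 1 of the 2 values shown sits, and therefore carries a direction but no firm size. Compound 3 `N#CC1=C(N)Oc2c(N)cc3nc4ccccc4nc3c2C12C(=O)N(Cc1cnnn1-c1cccc(Br)c1)c1ccccc12` is not yet measured; it differs from compound 2 by 3-bromophenyl in place of 2-chlorophenyl on an aromatic nitrogen. Going by the values given here, no measured step moves a halogen from one position of this phenyl ring to another, and the only step on record concerns a different substituent on the same ring, so it does not bear directly on this change. For compound 3 the expectation in this assay is a number near where compound 2 stands, with an estimated step of a number no higher from compound 2 to compound 3 (the limit leaves the size open) of no clear size either way. Compound 3 is expected at 50000 nM, within 20000 nM to 120000 nM, and may again be reported only as a limit.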

Compound 3, half-maximal inhibitory concentration: > 50000 nM
Compound 3: no number, only a limit; the forecaster's own chance of this, stated with the estimate: 60%; the middle value sits exactly at the limit.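

In this assay compound 3 gives > 50000 nM, which is a limit of the assay and not a number. The 3-bromophenyl group on the aromatic nitrogen gives an at least 2.1-fold higher number from compound 1 to compound 3 (0.33 log units; beyond the scatter), so compound 2 and compound 3, the two halogen-bearing phenyl members, both lie on the same side of compound 1, with no compound shown going against this. The step between compound 2 and compound 3 cannot be read because both values sit at the same limit: the limit of > 50000 nM in this assay, at which 2 of the 3 values shown sit.

Going by these compounds, compound 2 and compound 3 differ in both the halogen and its place on the phenyl ring, so the size of either change stays open. Also open, on these data alone, is how a phenyl ring carrying an amine, or a longer chain in place of the ethyl group of compound 1, would read in this assay.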